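This account rests on a few compounds, and the source may have more. Where it says the series, first, only, none or still open, it means among the compounds named here.

Compound 2 `CCCCCc1cc(C)c(C(=O)N=C(N)N)cc1S(C)(=O)=O` and compound 1 `Cc1cc(F)c(S(C)(=O)=O)cc1C(=O)N=C(N)N` share a core that carries an acylguanidine and a methylsulfonyl group; they differ only at one aromatic carbon, where compound 2 bears a pentyl chain and compound 1 a fluorine. Among the measured compounds shown here, in a functional assay for inhibition of sodium/hydrogen exchanger (Oryctolagus cuniculus) (on this read-out higher numbers stand for weaker inhibition and lower numbers for stronger inhibition), compound 2 gives 27 nM, the lowest of the two numbers so far, while compound 1 gives 44 nM; the step of a 1.6-fold lower number from compound 1 to compound 2 (0.21 log units; within the scatter) lies within the scatter, so the two cannot be told apart. Compound 3 `Cc1cc(-c2ccc(Cl)cc2Cl)c(S(C)(=O)=O)cc1C(=O)N=C(N)N` takes the next step at the same carbon: 2,4-dichlorophenyl in place of pentyl on an aromatic carbon. For the measured compounds named here, the only measured step touches this position and was small, which gives little ground to expect a large change. The number for compound 3 is therefore expected close to that of compound 2, with the estimated step of a 1.1-fold higher number from compound 2 to compound 3 (0.05 log units; within the scatter). For compound 3 in this assay the estimate is 30 nM, expected to fall between 9 nM and 100 nM.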

Compound 3, half-maximal inhibitory concentration: 42 nM
Compound 3: middle estimate off by 1.4-fold (0.15 log units), on the low side; the measured number falls inside the stated range.
By their numbers in this assay, from the lowest: compounds 2, 3 and 1 (each within the scatter of the next).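

In this assay the step of a 1.6-fold higher number from compound 2 to compound 3 (0.19 log units; within the scatter) and the step of a 1.0-fold lower number from compound 1 to compound 3 (0.02 log units; within the scatter) both lie within the scatter, so this carbon has now carried a fluorine atom, a chain and a ring with no measurable separation between the compounds. The 2,4-dichlorophenyl group brings one six-membered aromatic ring and two chlorine atoms, with 8 heavy atoms against 5 for pentyl, yet compound 3 cannot be told apart from compound 1 or compound 2 on this read-out. Nothing available here offers an explanation for this result.

Still open, on these data alone, is whether a group of a different kind at this carbon, such as an amine or a carboxylic acid, would stay within the scatter of these numbers or move beyond it. The same question remains for a longer chain and for a phenyl ring without chlorine atoms.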